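Chain Extension and Lipophilicity in a Bromomaleimide Indole Series

This account rests on a few compounds, and the source may have more. Where it says the series, first, only, none or still open, it means among the compounds named here.

Measured compounds:
- compound 1, `CCOc1ccc2[nH]c(-c3ccc(OC)cc3)c(C3=C(Br)C(=O)NC3=O)c2c1`: 2.77
- compound 2, `CCCOc1ccc2[nH]c(-c3ccc(OC)cc3)c(C3=C(Br)C(=O)NC3=O)c2c1`: 3.12
- compound 3, `CCCCc1ccc2[nH]c(-c3ccccc3)c(C3=C(Br)C(=O)NC3=O)c2c1`: 3.74

Of the compounds shown here, three have been measured in a physicochemical assay for lipophilicity (a higher number here means a more lipophilic compound, a lower number a more polar compound), and a fourth, compound 4, `CCCCCc1ccc2[nH]c(-c3ccccc3)c(C3=C(Br)C(=O)NC3=O)c2c1`, awaits measurement. Compound 1 and compound 2 share a core and differ only by methyl in place of hydrogen on a saturated chain carbon, two bonds along the chain from an oxygen on an aromatic ring; this change produced a step of a number 0.35 log units higher from compound 1 to compound 2 (beyond the scatter). Compound 3 carries a different core; the difference between the two cores is not broken down here. Its value in this assay is the highest of the three, lying beyond the scatter above both compound 2 and compound 1.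

Compound 4 differs from compound 3 by methyl in place of hydrogen on a saturated chain carbon, four bonds along the chain from an aromatic carbon. Among the measured compounds shown here, this is the same kind of change as the one from compound 1 to compound 2, but the surroundings are not identical: in the earlier pair the methyl entered two bonds along the chain from an oxygen on an aromatic ring, whereas here it enters four bonds along the chain from an aromatic carbon. Because the step of a number 0.35 log units higher from compound 1 to compound 2 (beyond the scatter) was modest and beyond the scatter, a step of roughly similar size is expected from compound 3 to compound 4, namely a number 0.45 log units higher from compound 3 to compound 4 (beyond the scatter). Compound 4 is therefore estimated to give 4.19 in this assay, with a plausible range from 3.85 to 4.55.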

Compound 4, partition coefficient: 4.07
Beside the measured number, compound 4's estimate is 0.12 log units above it; measured number inside the range.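

In this assay, the added methyl gave a number 0.33 log units higher from compound 3 to compound 4 (beyond the scatter), and the same kind of change on the core of compound 1 gave a number 0.35 log units higher from compound 1 to compound 2 (beyond the scatter), so in both of the pairs available the step was modest and in the same direction. This shows that the change carried over from one core to the other in these two pairs, but it does not show that the core has no influence: the pairs also differ in where the methyl enters, two bonds along the chain from an oxygen on an aromatic ring in one and four bonds along the chain from an aromatic carbon in the other, so the contributions of core and place cannot be separated, and two pairs establish no rule for the series. Nothing available explains why the two steps came out alike.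

The compounds shown leave open whether a longer chain, such as hexyl, on the core of compound 3 would give a step of similar size. They also leave open how the same methyl change would read on a chain carrying an amine or a carboxylic acid.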